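From Fluoro to Hydroxy on a Weak Kinase Binder

A few compounds are considered here, and "the series" means these few. Any claim that something is new, unique, unknown or untested is made for them only; others in the source may bear on it.

Two compounds share one core and differ only in where a fluorine sits on the outer ring. Compound 1, `Fc1ccccc1CNc1ccc2ccccc2n1`, was tested in an assay on isolated protein for binding affinity to tyrosine-protein kinase Tec (Homo sapiens) (on this read-out higher numbers stand for weaker binding and lower numbers for tighter binding), and gives 208000 nM. Compound 2, `Fc1cccc(CNc2ccc3ccccc3n2)c1`, gives 177000 nM in this assay. Compound 2 holds the lower of the two numbers, but compound 1 sits only slightly higher, a gap within the scatter, so the two are best read as equally weak binders.

The next compound is compound 3, `Oc1cccc(CNc2ccc3ccccc3n2)c1`, which has not yet been measured. It differs from compound 2 by hydroxy in place of fluoro on an aromatic carbon. Among the measured compounds shown here, no measured pair in this set shows what such a swap does, so any expectation rests only on the weak binding shared by compound 1 and compound 2. With a single small group exchanged on an already weak binder, the change expected in this assay is a 1.2-fold lower number from compound 2 to compound 3 (0.07 log units; within the scatter), with no clear direction beyond the scatter. Compound 3 is therefore expected to give about 150000 nM in this assay, most likely between 50000 nM and 450000 nM.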

Compound 3, dissociation constant: 234000 nM
Compound 3: the middle estimate sits 1.6-fold (0.19 log units) below what was measured; low and high end bracket the measured number.
By their numbers in this assay, from the lowest: compounds 2, 1 and 3 (each within the scatter of the next).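

Going from fluoro to hydroxy on this aromatic carbon gives a 1.3-fold higher number from compound 2 to compound 3 (0.12 log units; within the scatter) in this assay, so this exchange leaves no readable mark on binding. Among the compounds shown here, this is the first step in the set that replaces the group itself, and although hydroxy carries 1 hydrogen-bond donor and 1 hydrogen-bond acceptor where fluoro carries 0 of each, that difference in the counts comes with no clear gain or loss, and compound 3 remains a very weak binder at 234000 nM. No measurement available here offers an explanation for this flat result.

A single pair cannot show whether this position is insensitive to every exchange or only to this one, and an amine, a carboxylic acid or a methoxy group on the same aromatic carbon would test that more widely. As far as these compounds go, it also remains open whether the same swap would stay as silent on a different aromatic carbon of this ring, or in a compound that binds far more tightly than compound 2 does.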